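The source may hold more compounds than are shown below. What is called first, only, known or untested is meant among the compounds shown, and "the series" means these compounds.

Compound 1 `CCCCCCCC/C=C\CCCCCCCC[Se]C[C@H](N)C(=O)NCc1ccc(O)c(OC)c1` carries a long unsaturated chain joined through a selenium atom to a short amino-bearing link, which ends in an amide to the shared core. In an assay on HEK293 cells for antagonist activity at transient receptor potential cation channel subfamily V member 2 (Rattus norvegicus), read by fluorescence and calcium flux, with a stated time of 5 min (on this read-out higher numbers stand for weaker inhibition and lower numbers for stronger inhibition), compound 1 gives 1700 nM. Compound 2 `CCCCCCCC/C=C\CCCCCCCCSC[C@H](N)C(=O)NCc1ccc(O)c(OC)c1` has sulfur where compound 1 has selenium, and in this assay compound 2 gives 1900 nM. These two numbers lie within the usual scatter of each other, so compound 1 stands alongside compound 2 rather than apart from it. Compound 3 `CCCCCC[C@@H](O)C/C=C\CCCCCCCCSCCC(=O)NCc1ccc(O)c(OC)c1` lacks the amino group and also carries a hydroxyl on its chain. In this assay compound 3 reaches only the limit > 10000 nM, a boundary of the measurement rather than a number (the limit of > 10000 nM in this assay, at which 1 of the 3 values shown sits).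

Compound 4 `CCCCCCCC/C=C\CCCCCCCC[Se]CCC(=O)NCc1ccc(O)c(OC)c1` is compound 1 with hydrogen in place of amino on a saturated chain carbon bound to a carbonyl carbon and a saturated chain carbon. Among the measured compounds shown here, no measured pair shows this change on its own, and compound 3, the only measured compound without the amino group, differs in its chain as well. The step from compound 1 to compound 4 is nevertheless expected to be a 2.9-fold higher number from compound 1 to compound 4 (0.47 log units; beyond the scatter), toward weaker inhibition, since compound 3 without the amino group gives only a limit. Compound 4 is therefore estimated at 5000 nM, within a range from 1500 nM to 15000 nM, with a real chance that this assay returns only a limit for compound 4 as well.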

Compound 4, half-maximal inhibitory concentration: 1800 nM
Estimate against measurement, compound 4: 2.8-fold (0.44 log units) above; the range from low to high includes it.
By their numbers in this assay, from the lowest: compounds 1, 4 and 2 (each within the scatter of the next). At a limit, above all of these: compound 3.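

In this assay, the amino group on this saturated chain carbon, bound to a carbonyl carbon and a saturated chain carbon, proves dispensable in the selenium compound: hydrogen in its place gives a 1.1-fold higher number from compound 1 to compound 4 (0.02 log units; within the scatter). Before this pair, the change had never been seen on its own, and the only compound without the amino group, compound 3, also carried a hydroxyl on its chain and sulfur in place of selenium. Losing the amino group alone therefore does not bring the selenium compound to the limit seen for compound 3, which stays a limit rather than a number: the limit of > 10000 nM in this assay, at which 1 of the 4 values shown sits.

Still open, going by these compounds, is whether the hydroxyl on the chain of compound 3, the sulfur in that compound, or the two together go with that limit, and whether removing the amino group from sulfur-linked compound 2 would also leave the number within the scatter. Equally open, on these data alone, is how a carboxylic acid or a dimethylamino group would behave on this same carbon, compared with the amino group and hydrogen.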